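Trimming the Benzyl Sulfide Back to an Ethyl

A few compounds are considered here, and "the series" means these few. Any claim that something is new, unique, unknown or untested is made for them only; others in the source may bear on it.

In an ADME assay on L929 cells (Mus musculus) for antiproliferative activity, read by CCK-8 assay, with a stated time of 48 h (a lower number here means a stronger inhibitor, a higher number a weaker inhibitor), compound 2 `Cc1ccccc1CSc1n[nH]c(-n2[se]c3ccccc3c2=O)n1` gives 15600 nM, the second highest of the three numbers measured. Compound 3 `O=c1c2ccccc2[se]n1-c1nc(SCc2ccc([N+](=O)[O-])cc2)n[nH]1` gives 7430 nM, and compound 1 `CC(C)Sc1n[nH]c(-n2[se]c3ccccc3c2=O)n1` gives 37100 nM. Compound 4 `CCSc1n[nH]c(-n2[se]c3ccccc3c2=O)n1` differs from compound 2 by methyl in place of 2-methylphenyl on a saturated chain carbon bound to a sulfur. Among the measured compounds shown here, the one measured step that bears on this is the same kind of change run the other way: a 2.4-fold lower number from compound 1 to compound 2 (0.38 log units; beyond the scatter), so growing the group on the sulfur from isopropyl to 2-methylbenzyl lowered the number modestly. Cutting that group back to ethyl should move the number back up by a similar amount, toward compound 1. Compound 4 is therefore expected to give a higher number than compound 2, a step of a 2.2-fold higher number from compound 2 to compound 4 (0.35 log units; beyond the scatter). The estimate for compound 4 is 35000 nM, between 15000 nM and 80000 nM.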

Compound 4, half-maximal inhibitory concentration: 35200 nM
Estimate against measurement, compound 4: 1.0-fold (0.00 log units) below; low and high end bracket the measured number.
By their numbers in this assay, from the lowest: compound 3; then compound 2; then compounds 4 and 1 (each within the scatter of the next).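

Within this assay, ethyl and isopropyl on the sulfur cannot be told apart: swapping one for the other gives a 1.1-fold lower number from compound 1 to compound 4 (0.02 log units; within the scatter) and so the branch shows no measurable effect. Trimming 2-methylbenzyl to ethyl gives a 2.3-fold higher number from compound 2 to compound 4 (0.35 log units; beyond the scatter) and so the lower number of compound 2 goes with the larger group that carries the ring. Nothing shown here explains why this is so.

Still open, as far as these compounds go, is whether a plain benzyl would match 2-methylbenzyl, so the ring's methyl may or may not matter. A longer chain such as butyl, or an amine at the chain's end, could also show whether the ring itself is needed.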